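Swapping a Sulfonamide for an Amide on the Shared Core

A few compounds are considered here, and "the series" means these few. Any claim that something is new, unique, unknown or untested is made for them only; others in the source may bear on it.

Three compounds share one core and differ only in what sits on a single aromatic carbon. Compound 1 `CCCS(=O)(=O)Nc1cccc2c1CCC2c1ncc[nH]1` carries a (propylsulfonyl)amino group, compound 2 `c1ccc2c(c1)CCC2c1ncc[nH]1` carries hydrogen there, and compound 3 `CS(=O)(=O)Nc1cccc2c1CCC2c1ncc[nH]1` carries methanesulfonamido. In a functional assay on CHO cells for agonist activity at Alpha-1A adrenergic receptor (Homo sapiens), read by FLIPR and calcium flux (on this read-out lower numbers stand for smaller maximal responses and higher numbers for larger maximal responses), compound 1 gives 54%, compound 2 gives 54%, and compound 3 gives 87%. Compound 3 stands highest of the three: a number 33 percentage points higher from compound 1 to compound 3 (beyond the scatter) and a number 33 percentage points higher from compound 2 to compound 3 (beyond the scatter), whereas no change at the digits printed from compound 1 to compound 2 (within the scatter).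

Compound 4 `CNC(=O)c1cccc2c1CCC2c1ncc[nH]1` is the next step from compound 3: methylcarbamoyl in place of methanesulfonamido on an aromatic carbon. Going by the values given here, no measured step involves a methylcarbamoyl group, so the steps that bear on it do so only indirectly. The two large steps into compound 3 show that the methanesulfonamido group alone sets compound 3 apart from compound 1 and compound 2, while the bare core of compound 2 and the larger sulfonamide of compound 1 sit together within the scatter of each other. Taking that group away and putting a different one in its place is therefore expected to give up part of the gain: the expected step is a number 22 percentage points lower from compound 3 to compound 4 (beyond the scatter), downward but not all the way to the bare core. Compound 4 is expected at 65%, between 45% and 88%.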

Compound 4, largest response reached (Emax), in percent of the reference or control that the assay uses: 59%
Estimate against measurement, compound 4: 6 percentage points above; low and high end bracket the measured number.
By their numbers in this assay, from the lowest: compounds 1, 2 and 4 (each within the scatter of the next); then compound 3.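

Putting methylcarbamoyl on this aromatic carbon does not preserve the high maximal response of compound 3: in this assay, the swap gives a number 28 percentage points lower from compound 3 to compound 4 (beyond the scatter), even though the group that leaves and the group that enters each count 1 hydrogen-bond donor. The new group also fails to separate from the other two substituents, with a number 5 percentage points higher from compound 2 to compound 4 (within the scatter) and a number 5 percentage points higher from compound 1 to compound 4 (within the scatter), so among the four compounds only methanesulfonamido stands apart, and compound 1 shows that a sulfonamide with a propyl chain does not share that result. Nothing measured here explains why methanesulfonamido differs from methylcarbamoyl at this position.

The compounds shown leave open how the response changes along the chain on the sulfonyl between methyl and propyl, a question that an (ethylsulfonyl)amino group would address. They also leave open whether acetamido, an amide joined to the aromatic carbon through its nitrogen as the sulfonamide of compound 3 is, would behave like methanesulfonamido or like methylcarbamoyl.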